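The compounds below may be only part of what the source reports. "The series", "measured", "known", "first", "only" and "open" are said of these compounds alone.

Of the compounds shown here, three from one series have been tested in a functional assay on MIA PaCa-2 cells (Homo sapiens) for inhibition, read by MTT assay, with a stated time of 72 h; on this read-out higher numbers stand for weaker inhibition and lower numbers for stronger inhibition. Compound 1, `CC(C)(C)OC(=O)N1CCC[C@H]1COCCCCCC/C=C/c1ccc(-c2ccccc2)cc1`, gives 23000 nM in this assay. Compound 3, `CC(C)(C)OC(=O)N1CCC[C@H]1COCCCCCC/C=C/c1ccc(Oc2ccccc2)cc1`, differs from compound 1 in one place: phenoxy in place of phenyl on an aromatic carbon. Compound 3 gives 8500 nM. That change brought a 2.7-fold lower number from compound 1 to compound 3 (0.43 log units; beyond the scatter). Compound 2, `CC(C)(C)OC(=O)N1CCC[C@H]1COCCCCCCCCC/C=C/c1ccc(-c2ccccc2)cc1`, gives 57400 nM in this assay, the highest of the three numbers; the difference between the core of compound 2 and the core of compound 1 is not broken down here. Compound 4, `CC(C)(C)OC(=O)N1CCC[C@H]1COCCCCCCCCC/C=C/c1ccc(Oc2ccccc2)cc1`, has not yet been measured. It differs from compound 2 in one place: phenoxy in place of phenyl on an aromatic carbon. The place is described in the same words as for the pair of compound 1 and compound 3, so this is the same change, seen only once before among these compounds. For compound 4 the expected step is a 2.7-fold lower number from compound 2 to compound 4 (0.44 log units; beyond the scatter), which rests on that single earlier instance, a 2.7-fold lower number from compound 1 to compound 3 (0.43 log units; beyond the scatter), and on compound 2 having shown 57400 nM. On that basis compound 4 is estimated at 21000 nM, with a likely range from 9000 nM to 50000 nM.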

Compound 4, half-maximal inhibitory concentration: 59600 nM
The estimate for compound 4 lay 2.8-fold (0.45 log units) below the measured number; measured number above the stated range.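

The swap of phenyl for phenoxy lowered the number on the core of compound 1, but on the other core it brought a 1.0-fold higher number from compound 2 to compound 4 (0.02 log units; within the scatter), so its effect cannot simply be carried from one core to another as a fixed step. In this assay the two results really do differ: the same change on two cores in this assay, a 2.7-fold lower number (0.43 log units; beyond the scatter) from compound 1 to compound 3 and a 1.0-fold higher number (0.02 log units; within the scatter) from compound 2 to compound 4, 2.8-fold (0.45 log units) apart, beyond the scatter of two such steps

Among these compounds, with only one pair on each core, this shows that the size of the step changed with the core in these compounds, but it does not show why, or what the same swap would do on any third core.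

As far as these compounds go, it remains open how a methoxy group or an amine would compare with phenyl and phenoxy on the same aromatic carbon. Also open, from the compounds shown here alone, is how the swap behaves with a shorter chain than either core carries, which would help show whether the step seen on the core of compound 1 is the exception or the rule.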